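Chlorophenyl Position Swap Carried onto a Second Core

This account rests on a few compounds, and the source may have more. Where it says the series, first, only, none or still open, it means among the compounds named here.

Compound 1 `O=c1[nH]cc(S(=O)(=O)Nc2ccccc2-c2cn(-c3cccc(Cl)c3)nn2)c(=O)[nH]1` gives 2340 nM in a functional assay on A549 cells (Homo sapiens) for antiproliferative activity, read by MTT assay, with a stated time of 24 h; on this read-out lower numbers stand for stronger inhibition and higher numbers for weaker inhibition.
Compound 2 `O=c1[nH]cc(S(=O)(=O)Nc2ccccc2-c2cn(-c3ccc(Cl)cc3)nn2)c(=O)[nH]1` gives 1180 nM in this assay.
Compound 3 `O=c1[nH]cc(S(=O)(=O)Nc2cccc(-c3cn(-c4cccc(Cl)c4)nn3)c2)c(=O)[nH]1` gives 2430 nM in this assay.

Three compounds share a sulfonamide-linked triazole bearing a chlorophenyl group, and they were measured in this assay. Compounds 1 and 2 differ in one place: 4-chlorophenyl in place of 3-chlorophenyl on an aromatic nitrogen. The step between them is a 2.0-fold lower number from compound 1 to compound 2 (0.30 log units; within the scatter), so the two numbers are not told apart by this measurement.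

Compound 3 carries the same 3-chlorophenyl group as compound 1 but on a differently joined core; how the two cores differ is not broken down here. The values of compound 3 and compound 1 sit within the scatter of each other, while compound 3 against compound 2 shows a gap that is beyond it.

Compound 4 `O=c1[nH]cc(S(=O)(=O)Nc2cccc(-c3cn(-c4ccc(Cl)cc4)nn3)c2)c(=O)[nH]1` has not yet been measured. It stands to compound 3 as compound 2 stands to compound 1: 4-chlorophenyl in place of 3-chlorophenyl on an aromatic nitrogen. The place lines of the two changes read the same, so this is the same change made on the second core.

Because the earlier change gave a 2.0-fold lower number from compound 1 to compound 2 (0.30 log units; within the scatter), a step of about the same size is expected here, a 1.9-fold lower number from compound 3 to compound 4 (0.27 log units; within the scatter), though a step within the scatter may equally well not repeat. Compound 4 is therefore estimated at 1300 nM, with the range 600 nM to 3000 nM expected to hold most repeat measurements.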

Compound 4, half-maximal inhibitory concentration: 1730 nM
Estimate against measurement, compound 4: 1.3-fold (0.12 log units) below; the range from low to high includes it.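

In this assay, 4-chlorophenyl in place of 3-chlorophenyl on the second core gives a 1.4-fold lower number from compound 3 to compound 4 (0.15 log units; within the scatter), so this measurement does not tell compound 3 and compound 4 apart. Set beside the same change on the core of compound 1, the new step does not differ from the earlier one in size: the same change on two cores in this assay, a 2.0-fold lower number (0.30 log units; within the scatter) from compound 1 to compound 2 and a 1.4-fold lower number (0.15 log units; within the scatter) from compound 3 to compound 4, 1.4-fold (0.15 log units) apart, within the scatter of two such steps. This shows that the two cores give consistent readings for this one change, with no step beyond the scatter on either, but with each step within the scatter it does not show that the swap of chlorophenyl groups has a real effect on either core, nor that the agreement would extend to any other core in the series.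

Throughout these four compounds the only group varied on the aromatic nitrogen is a chlorophenyl, and the sulfonamide link and the ring bearing it stay the same. On these data alone, what remains open is what a methoxyphenyl, an aminophenyl or an unsubstituted phenyl in that place would give in this assay, and whether any such group would open a step beyond the scatter on both cores.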